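Swapping a benzyl for a phenyl on the shared core

A few compounds are considered here, and "the series" means these few. Any claim that something is new, unique, unknown or untested is made for them only; others in the source may bear on it.

Of the compounds shown here, three with a shared chlorinated core have been tested in a functional assay on Jurkat cells (Homo sapiens) for inhibition, read by CCK-8 assay, with a stated time of 48 h; a higher number here means a weaker inhibitor of growth, a lower number a stronger inhibitor of growth. Compound 1 `Cc1ccccc1Nc1nc(Nc2ccccn2)ncc1Cl` gives 20100 nM and compound 2 `Cc1ccccc1Nc1nc(Nc2ccc(N3CCN(C)CC3)cc2)ncc1Cl` gives 13700 nM. Compound 3 `CN1CCN(c2ccc(Nc3ncc(Cl)c(NCc4ccc(C(F)(F)F)cc4)n3)nc2)CC1` gives 7960 nM, the lowest of the three numbers, though its gap to compound 2 lies within the usual scatter and only the gap to compound 1 lies beyond it.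

Compound 4 `CCc1ccc(Nc2nc(Nc3ccc(N4CCN(C)CC4)cn3)ncc2Cl)cc1` is not yet measured. It differs from compound 3 by one change: 4-ethylphenyl in place of 4-(trifluoromethyl)benzyl on a nitrogen on an aromatic ring. Going by the values given here, no measured pair here shows the effect of such a change, so no step beyond the scatter is expected from compound 3 to compound 4; the estimated step is a 1.1-fold lower number from compound 3 to compound 4 (0.03 log units; within the scatter). Compound 4 is therefore expected to give about 7500 nM, within 2500 nM to 22000 nM.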

Compound 4, concentration for 50% growth inhibition: 11100 nM
For compound 4 the middle estimate is 1.5-fold (0.17 log units) below the measured one, and the stated range covers the measured number.
By their numbers in this assay, from the lowest: compounds 3, 4, 2 and 1 (each within the scatter of the next, the first and the last beyond it).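

In this assay, going by these compounds alone, this is the first direct test of the position, a nitrogen on an aromatic ring: 4-ethylphenyl in place of 4-(trifluoromethyl)benzyl gives a 1.4-fold higher number from compound 3 to compound 4 (0.14 log units; within the scatter) and so no change that can be told from the scatter. Both groups carry a six-membered aromatic ring of carbon only, and this one pair shows that they are not told apart here. Nothing measured here explains this result.

Going by these compounds, whether a group with a carboxylic acid or an amine on that ring would behave the same remains open. So does the effect of a longer chain at this nitrogen.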